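The source may report more compounds than this note shows. Statements on the series, on what has been measured and on what is new or still open speak of the compounds shown alone.

Measured compounds in a functional assay on MCF7 cells (Homo sapiens) for inhibition, read by MTT assay, with a stated time of 72 h; on this read-out higher numbers stand for weaker inhibition and lower numbers for stronger inhibition:

- compound 1 `Cc1cccc(Nc2nc(SCc3cn(Cc4ccccc4Cl)nn3)nc(-c3ccccc3)c2C#N)c1` gives 19600 nM
- compound 2 `Cc1ccc(Cn2cc(CSc3nc(Nc4ccccc4C)c(C#N)c(-c4ccccc4)n3)nn2)cc1` gives > 64000 nM
- compound 3 `Cc1ccc(Nc2nc(SCc3cn(Cc4ccc(F)cc4)nn3)nc(-c3ccccc3)c2C#N)cc1` gives 51100 nM

Compound 2 reports only a limit of the assay, not a number, and sits at the ceiling noted in the limit of > 64000 nM in this assay, at which 1 of the 3 values shown sits. Among the two numbers, compound 3 stands highest in this assay, with compound 1 the nearest neighbour at a lower value, a gap beyond the usual scatter. Compound 3 and compound 2 share the same core but differ at two places, so their two values show only that both lie in the weak range.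

Compound 4 `Cc1ccc(Cn2cc(CSc3nc(Nc4ccc(C)cc4)c(C#N)c(-c4ccccc4)n3)nn2)cc1` is not yet measured. It differs from compound 3 by methyl in place of fluoro on an aromatic carbon, reading 4-fluorobenzyl to 4-methylbenzyl. The same 4-methylbenzyl group is present in compound 2, which gives only a limit. The step is expected to be small or none beyond the scatter, if anything towards weaker inhibition, as a 1.3-fold higher number from compound 3 to compound 4 (0.10 log units; within the scatter). Compound 4 is estimated at 64000 nM, range 28000 nM to 150000 nM, with a real chance that the assay returns only a limit.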

Compound 4, half-maximal inhibitory concentration: > 64000 nM
Compound 4: no number, only a limit; the forecaster's own chance of this, stated with the estimate: 50%; the middle value lies on the limit itself.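

In this assay compound 4 returns only a limit, > 64000 nM. Methyl in place of fluoro, reading 4-fluorobenzyl to 4-methylbenzyl, gives an at least 1.2-fold higher number from compound 3 to compound 4 (0.09 log units; that floor lies within the scatter), so only a floor on the step is known, and that floor does not separate the change from no change. Both compounds carrying 4-methylbenzyl, compound 2 and compound 4, now sit at the ceiling, and the step between them cannot be read: the limit of > 64000 nM in this assay, at which 2 of the 4 values shown sit.

Going by these compounds, how far compound 4 lies past the limit stays open, and with it the true size of the change from fluoro to methyl. Also open, on these data alone, is whether an amine or a carboxylic acid at this place on the benzyl group would bring the value down to a readable number.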